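The compounds below may be only part of what the source reports. "The series", "measured", "known", "first", "only" and "open" are said of these compounds alone.

Series notes. Compound 1 `CCNCC(=O)Nc1cc(OC)ccc1C(=O)c1ccc(OC)c2c1OC(C)(C)C=C2` and compound 2 `COc1ccc(C(=O)c2ccc(OC)c3c2OC(C)(C)C=C3)c(NC(=O)CN(C)C)c1` share one core; compound 3 `C=C(c1cc(OC)c(OC)c(OC)c1)c1ccc(OC)cc1NC(=O)CNCC` and compound 4 `C=C(c1cc(OC)c(OC)c(OC)c1)c1ccc(OC)cc1NC(=O)CN(C)C` share another, and the difference between the two cores is not broken down here. In a functional assay on A549 cells (Homo sapiens) for antiproliferative activity, read by MTT assay, with a stated time of 48 h (a higher number here means a weaker inhibitor, a lower number a stronger inhibitor), compound 1 gives 1050 nM. In this assay compound 2 gives 890 nM. The change from compound 1 to compound 2 is dimethylamino in place of ethylamino on a saturated chain carbon bound to a carbonyl carbon, and the step it made was a 1.2-fold lower number from compound 1 to compound 2 (0.07 log units; within the scatter). In this assay compound 3 gives 260 nM, the lowest number among the three measured compounds, with its gaps to compound 2 and to compound 1 both beyond the scatter. Compound 4 carries the same change on the other core: dimethylamino in place of ethylamino on a saturated chain carbon bound to a carbonyl carbon, made at the same place as in the first pair. Within the data shown here, the only precedent for this change is a 1.2-fold lower number from compound 1 to compound 2 (0.07 log units; within the scatter), a step that stayed within the scatter. On that basis the step expected here is a 1.1-fold lower number from compound 3 to compound 4 (0.05 log units; within the scatter), with no evidence that the change acts differently on the core of compound 3. Compound 4 is therefore expected to give an estimated 230 nM in this assay, with a likely range from 120 nM to 450 nM.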

Compound 4, half-maximal inhibitory concentration: 130 nM
The estimate for compound 4 lay 1.8-fold (0.25 log units) above the measured number; measured number inside the range.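

In this assay the new pair gives a 2.0-fold lower number from compound 3 to compound 4 (0.30 log units; within the scatter), so dimethylamino in place of ethylamino on a saturated chain carbon bound to a carbonyl carbon stays within the scatter on this core, as it did on the core of compound 1. The two pairs give no sign that the change behaves differently from one core to the other: the same change on two cores in this assay, a 1.2-fold lower number (0.07 log units; within the scatter) from compound 1 to compound 2 and a 2.0-fold lower number (0.30 log units; within the scatter) from compound 3 to compound 4, 1.7-fold (0.23 log units) apart, within the scatter of two such steps. This is agreement between two pairs in a single cell assay; it does not show that the change would stay this small on any further core, and it does not settle whether a real but small step lies hidden within the scatter.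

The compounds shown leave open how other amines at this place would read, such as a primary amine, a pyrrolidine or a morpholine, and what a longer chain carrying the dimethylamino group would do. They also leave open how much of the gap between the two cores comes from any single part of those cores.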